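The compounds below may be only part of what the source reports. "The series", "measured", "known", "first", "only" and "open" are said of these compounds alone.

Compound 1, `CN1CCN(CCNC(=O)n2c(=O)n(Cc3ccccc3)c3ccccc32)CC1`: < 6
Compound 2, `C=CCn1c(=O)n(C(=O)NCCN2CCN(C)CC2)c2ccccc21`: < 6

In a functional assay for antagonist activity at 5-hydroxytryptamine receptor 4 (Cavia porcellus) (a lower number here means a less potent compound, a higher number a more potent compound, by a factor of ten per unit of this negative logarithm), compound 1 gives < 6, which is a limit of the assay rather than a measured number. Compound 2 gives < 6, again a limit and not a number. With both ends sitting at the limit, the step that the two limits leave unreadable from compound 1 to compound 2 has no readable size, and nothing can be said about its direction. Both values sit at the limit of < 6 in this assay, at which 2 of the 2 values shown sit, so the two measured compounds carry no information about how this part of the structure influences potency.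

Compound 3, `CN1CCN(CCNC(=O)n2c(=O)n(C)c3ccccc32)CC1`, has not been measured in this assay. It differs from compound 2 by hydrogen in place of vinyl on a saturated chain carbon bound to an aromatic nitrogen; cut one bond further out, the same change reads allyl to methyl. Among the measured compounds shown here, no measured step bears on this change in a readable way, and nothing in the measured values points to a gain in potency. Compound 3 is therefore expected to stay at or near the limit, with an estimate of 5.5 and a range from 4.5 to 6.3. The step this estimate means, a step that the limit leaves unreadable from compound 2 to compound 3, is expected to be none beyond the scatter.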

Compound 3, negative logarithm of the antagonist equilibrium constant: < 6
Compound 3: only a limit was reported (the forecaster's own chance of this, stated with the estimate: 80%); the middle value lies beyond the limit too.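

In this assay compound 3 gives < 6, which is a limit of the assay and not a number. No step among compound 1, compound 2 and compound 3 can be read, since all three rest at the same limit: the limit of < 6 in this assay, at which 3 of the 3 values shown sit.

The compounds shown leave open whether phenyl, vinyl or hydrogen at this place changes potency at all.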